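The compounds below may be only part of what the source reports. "The series", "measured", "known", "first", "only" and "open" are said of these compounds alone.

Two compounds share one core and differ only in the group attached to the carbonyl carbon of the amide. Compound 1 `COc1ccc(C(=O)Nc2cccc(-c3oc4cc(-c5ccc(F)cc5)ccc4c(=O)c3O)c2)cc1` carries a 4-methoxyphenyl there, and in a functional assay on GTL 16 cells for antiproliferative activity against GTL 16 cell line (Homo sapiens), read by CCK-8 assay, with a stated time of 72 h (a lower number here means a stronger inhibitor, a higher number a weaker inhibitor), compound 1 gives 21100 nM. Compound 2 `Cc1ccccc1C(=O)Nc1cccc(-c2oc3cc(-c4ccc(F)cc4)ccc3c(=O)c2O)c1` carries a 2-methylphenyl instead, and in this assay compound 2 gives 24800 nM. On paper that is the larger of the two numbers, but the step of a 1.2-fold higher number from compound 1 to compound 2 (0.07 log units; within the scatter) lies within the scatter, so the two compounds cannot be separated. Compound 3 `O=C(Nc1cccc(-c2oc3cc(-c4ccc(F)cc4)ccc3c(=O)c2O)c1)c1ccc(Br)cc1` is the next member: 4-bromophenyl in place of 2-methylphenyl on a carbonyl carbon. Going by the values given here, the only measured step that bears on this change also swaps one phenyl group for another on the same carbonyl carbon, and it moved the number hardly at all. On that basis compound 3 is expected to stay close to its neighbours, with a step of a 1.2-fold lower number from compound 2 to compound 3 (0.09 log units; within the scatter) that is expected to remain within the scatter. The estimate for compound 3 in this assay is 20000 nM, within a range from 8000 nM to 50000 nM.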

Compound 3, half-maximal inhibitory concentration: 25400 nM
Compound 3: middle estimate off by 1.3-fold (0.10 log units), on the low side; the measured number falls inside the stated range.
By their numbers in this assay, from the lowest: compounds 1, 2 and 3 (each within the scatter of the next).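

In this assay, the step of a 1.0-fold higher number from compound 2 to compound 3 (0.01 log units; within the scatter) lies within the scatter, as does the step of a 1.2-fold higher number from compound 1 to compound 3 (0.08 log units; within the scatter), so compounds 1, 2 and 3 cannot be separated. The new information is that 4-bromophenyl joins 4-methoxyphenyl and 2-methylphenyl on this carbonyl carbon with no readable shift, and that bromo in place of methoxy on an aromatic carbon also leaves the number unchanged within the scatter. No supporting measurement is available to explain this flat result.

On these data alone, all three compounds carry a substituted phenyl group at this position, so it remains open whether an aliphatic amine, a carboxylic acid or a longer alkyl chain there would move the number beyond the scatter. They also leave open how the number responds to changes elsewhere on the shared core.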